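A few compounds are considered here, and "the series" means these few. Any claim that something is new, unique, unknown or untested is made for them only; others in the source may bear on it.

Compound 1 `CO/N=c1\[nH]cnc2c1[n+](C/C=C(\C)CC/C=C(/C)CCC=C(C)C)cn2C` and compound 3 `CO/N=c1\[nH]cnc2c1[n+](C/C=C(\C)CC/C=C(\C)CC/C=C(\C)CCC=C(C)C)cn2Cc1ccccc1` carry different cores; the difference between the two cores is not broken down here. In a functional assay on cells (Homo sapiens) for cytotoxicity (on this read-out higher numbers stand for weaker inhibition and lower numbers for stronger inhibition), compound 1 gives 736 nM, and compound 3 gives 1040 nM; the two numbers lie within the scatter of each other. Compound 2 `CC(C)=CCC/C(C)=C\CC/C(C)=C/C[n+]1cn(C)c2nc[nH]/c(=N\OCc3ccccc3)c21` differs from compound 1 by phenyl in place of hydrogen on a saturated chain carbon bound to an oxygen. In this assay compound 2 gives 6760 nM, a step of a 9.2-fold higher number from compound 1 to compound 2 (0.96 log units; beyond the scatter).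

Compound 4 `CO/N=c1\[nH]cnc2c1[n+](C/C=C(\C)CC/C=C(\C)CC/C=C(\C)CCC=C(C)C)cn2C(c1ccccc1)c1ccccc1` is not yet measured. It differs from compound 3 by phenyl in place of hydrogen on a saturated chain carbon bound to an aromatic carbon and an aromatic nitrogen. This is the same kind of change as that from compound 1 to compound 2, but the place differs: there the saturated chain carbon is bound to an oxygen, here it is bound to an aromatic carbon and an aromatic nitrogen. Among the compounds with values here, only one measured instance of this change exists, so any expectation rests on it alone. Because of the step of a 9.2-fold higher number from compound 1 to compound 2 (0.96 log units; beyond the scatter), the same kind of change is expected to move compound 4 toward a higher number, estimated as a 4.8-fold higher number from compound 3 to compound 4 (0.68 log units; beyond the scatter). The estimate for compound 4 in this assay is 5000 nM, expected to fall between 1500 nM and 15000 nM.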

Compound 4, half-maximal inhibitory concentration: 2600 nM
For compound 4 the middle estimate is 1.9-fold (0.28 log units) above the measured one; low and high end bracket the measured number.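

Carrying phenyl in place of hydrogen to a second core in this assay keeps the direction, with a 2.5-fold higher number from compound 3 to compound 4 (0.40 log units; beyond the scatter), so both instances shown end at a higher number. The size does not carry over: the same change on two cores in this assay, a 9.2-fold higher number (0.96 log units; beyond the scatter) from compound 1 to compound 2 and a 2.5-fold higher number (0.40 log units; beyond the scatter) from compound 3 to compound 4, 3.7-fold (0.57 log units) apart, beyond the scatter of two such steps. One step is therefore a poor guide to the size of the same change on another core, but two instances give no general rule, and the steps differ both in core and in place (a saturated chain carbon bound to an oxygen, against one bound to an aromatic carbon and an aromatic nitrogen), so the gap can be assigned to neither.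

The compounds shown leave open whether a step of this kind on one fixed core depends on place alone, which would need both places compared on the same core. Within the data shown here, they also leave open how an amine or a carboxylic acid in place of that hydrogen would read in this assay, since phenyl is the only entering group here.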